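Oxygen substituent on the saturated ring: sulfonate to carbamate

This account rests on a few compounds, and the source may have more. Where it says the series, first, only, none or still open, it means among the compounds named here.

Three analogues sharing one core differ only in the group on an oxygen on a saturated carbon. Compound 1 `COC1C[C@@H]2CCCC[C@@H]2[C@H]1/C=C/c1ccc(-c2cccc(F)c2)cn1` carries methyl there and gives 67 nM in an assay on cell membranes for displacement of a labelled ligand from proteinase-activated receptor 1 (Homo sapiens), read by scintillation counting, with a stated time of 60 min; a higher number here means a weaker inhibitor, a lower number a stronger inhibitor. Compound 2 `CC(=O)OC1C[C@@H]2CCCC[C@@H]2[C@H]1/C=C/c1ccc(-c2cccc(F)c2)cn1` carries acetyl and gives 67 nM; the step of no change at the digits printed from compound 1 to compound 2 (within the scatter). Compound 3 `CS(=O)(=O)OC1C[C@@H]2CCCC[C@@H]2[C@H]1/C=C/c1ccc(-c2cccc(F)c2)cn1` carries methylsulfonyl and gives 6.4 nM, the lowest of the three numbers; the steps of a 10-fold lower number from compound 1 to compound 3 (1.02 log units; beyond the scatter) and a 10-fold lower number from compound 2 to compound 3 (1.02 log units; beyond the scatter).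

Compound 4 `O=C(Nc1ccccc1)OC1C[C@@H]2CCCC[C@@H]2[C@H]1/C=C/c1ccc(-c2cccc(F)c2)cn1` is the next member: phenylcarbamoyl in place of methylsulfonyl on an oxygen on a saturated carbon. Going by the values given here, the two steps that bear on it are those into compound 3, from methyl and from acetyl, both large and both towards a lower number; the carbamate itself is not covered by any measured pair, so there is no direct precedent for phenylcarbamoyl on this oxygen. Since only methylsulfonyl has so far given the low number of compound 3, and acetyl sat with methyl, the expectation is that compound 4 gives up part of that gain and moves back towards compounds 1 and 2, with wide uncertainty: the estimated step is a 4.7-fold higher number from compound 3 to compound 4 (0.67 log units; beyond the scatter). Compound 4 is therefore expected to give about 30 nM in this assay, within a range of 8 nM to 120 nM.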

Compound 4, half-maximal inhibitory concentration: 360 nM
Compound 4: middle estimate off by 12-fold (1.08 log units), on the low side, outside the stated range (above it).
By their numbers in this assay, from the lowest: compound 3; then compounds 1 and 2 (each within the scatter of the next); then compound 4.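

In this assay this oxygen on a saturated carbon proves sensitive in both directions: phenylcarbamoyl in place of methylsulfonyl gives a 56-fold higher number from compound 3 to compound 4 (1.75 log units; beyond the scatter), and the new group also stands apart from the two smaller groups, with a 5.4-fold higher number from compound 1 to compound 4 (0.73 log units; beyond the scatter) and a 5.4-fold higher number from compound 2 to compound 4 (0.73 log units; beyond the scatter). The earlier compounds shown here showed only a gain with methylsulfonyl and no separation of methyl from acetyl; the step from acetyl, read as anilino in place of methyl on a carbonyl carbon, now shows that a change on the carbonyl carbon alone can move the number away from the level of compounds 1 and 2. Nothing available on these compounds accounts for the order seen at this position.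

The phenylcarbamoyl group brings in an aromatic ring and an amide hydrogen together, so methylcarbamoyl, benzoyl and N-methyl-N-phenylcarbamoyl would be needed to tell which part goes with the higher number. On these data alone, whether the low number of compound 3 belongs to methylsulfonyl alone or extends to other sulfonates remains open, and ethylsulfonyl and phenylsulfonyl on the same oxygen would address that.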